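Swapping a Bicyclic Amide Group for tert-Butyl

A few compounds are considered here, and "the series" means these few. Any claim that something is new, unique, unknown or untested is made for them only; others in the source may bear on it.

Measured so far:
- compound 1 `CCCCCCCCCCCCn1nnc(C(C(=O)Nc2ncccc2C)c2ccccc2)n1`: 85 nM
- compound 2 `CCCCCCCCCCCCn1nnc(C(C(=O)Nc2ccc3c(C)cc(C)nc3n2)c2ccccc2)n1`: 1540 nM

Both compounds share a core with a dodecyl chain on a tetrazole, a phenyl group and an amide; they differ only in the group on the amide nitrogen. In an assay on liver for inhibition of sterol O-acyltransferase 1 (Rattus norvegicus), using microsomes (on this read-out higher numbers stand for weaker inhibition and lower numbers for stronger inhibition), compound 1 gives 85 nM, while compound 2 gives 1540 nM. Compound 2 thus carries the highest number of the two, and the step of an 18-fold higher number from compound 1 to compound 2 (1.26 log units; beyond the scatter) is well beyond the scatter. Compound 3 `CCCCCCCCCCCCn1nnc(C(C(=O)NC(C)(C)C)c2ccccc2)n1` is not yet measured. The change is a group of 4 heavy atoms (4 carbon; no ring) in place of a group of 12 heavy atoms (10 carbon, 2 nitrogen; 2 six-membered aromatic rings with 1 hetero atom each), on an amide-type nitrogen. Going by the values given here, no measured step covers an aromatic-to-alkyl exchange at this position, so the only guidance is that the larger bicyclic group in compound 2 gave a much weaker result than the smaller pyridyl group in compound 1, as the step of an 18-fold higher number from compound 1 to compound 2 (1.26 log units; beyond the scatter) shows. Because of an 18-fold higher number from compound 1 to compound 2 (1.26 log units; beyond the scatter), removing that bicyclic group is expected to move the number downwards, toward the range of compound 1, though with broad uncertainty. For compound 3 the expected step is a 3.1-fold lower number from compound 2 to compound 3 (0.49 log units; beyond the scatter), giving an estimate of 500 nM within a range from 100 nM to 3000 nM.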

Compound 3, half-maximal inhibitory concentration: 3350 nM
The estimate for compound 3 lay 6.7-fold (0.83 log units) below the measured number; the whole stated range lies below it.
By their numbers in this assay, from the lowest: compound 1; then compound 2; then compound 3.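

The result shows that a smaller group on this amide-type nitrogen does not by itself bring a lower number: in this assay, tert-butyl in place of the group with two six-membered aromatic rings gives a 2.2-fold higher number from compound 2 to compound 3 (0.34 log units; beyond the scatter) and moves the number away from that of compound 1. Against the 3-methylpyridin-2-yl group, tert-butyl gives a 39-fold higher number from compound 1 to compound 3 (1.60 log units; beyond the scatter) and so makes the largest step among these compounds. Among these three groups, the number therefore does not simply follow group size: the middle-sized 3-methylpyridin-2-yl group has the lowest number, while both the larger group and the smaller tert-butyl have higher ones.

No available measurement explains these steps. Going by these compounds, it remains open whether the low number of compound 1 depends on the aromatic ring, its ring nitrogen or its methyl group, and a phenyl, 2-methylphenyl or cyclohexyl group on this nitrogen would be needed to separate those features.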